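From ethyl to cyclopropyl on the ring amine

A few compounds are considered here, and "the series" means these few. Any claim that something is new, unique, unknown or untested is made for them only; others in the source may bear on it.

In a physicochemical assay for solubility, at pH 7 (a lower number here means a less soluble compound, a higher number a more soluble compound), compound 1 (`CC1(C)c2[nH]nc(NC(=O)c3ccc(F)cc3)c2CN1C(=O)C1CCN(C2CC2)CC1`) carries the 1-cyclopropylpiperidin-4-yl group and gives > 225000 nM as a limit of the assay. Compound 2 (`CCN1CCC(C(=O)N2Cc3c(NC(=O)CC(C)C)n[nH]c3C2(C)C)CC1`) gives > 225000 nM as a limit too, not a number. Among the measured compounds shown here, the two stand together (the limit of > 225000 nM in this assay, at which 2 of the 2 values shown sit) and no measured step links them. Compound 3 (`CC(C)CC(=O)Nc1n[nH]c2c1CN(C(=O)C1CCN(C3CC3)CC1)C2(C)C`) has cyclopropyl in place of ethyl on an amine nitrogen in a ring. For the measured compounds named here, the limit of compound 1 (> 225000 nM) is the only guide to that group. In this assay the step is expected to stay within the scatter (a number no higher from compound 2 to compound 3 (the limit leaves the size open)). Compound 3 is estimated at 225000 nM with a range from 120000 nM to 300000 nM and may well report only a limit.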

Compound 3, solubility: > 225000 nM
Compound 3 ended at the assay's limit (the forecaster's own chance of this, stated with the estimate: 85%); the middle value lies on the limit itself.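

Compound 3 gives only a limit in this assay, so the steps to it from compound 1 and from compound 2 cannot be read: the limit of > 225000 nM in this assay, at which 3 of the 3 values shown sit. The compounds shown leave open how cyclopropyl and ethyl on the ring amine compare in this assay.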